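A few compounds are considered here, and "the series" means these few. Any claim that something is new, unique, unknown or untested is made for them only; others in the source may bear on it.

Compound 1 `Cc1cc(C)c(NC(=O)N(Cc2ccccc2)Cc2cccc(-c3cc[nH]n3)c2)c(C)c1` gives > 1 mg/kg in a functional assay on a cell-free system (plasma) with sterol O-acyltransferase, Soat (Rattus norvegicus) as the target (on this read-out higher numbers stand for an effect only at larger amounts of compound and lower numbers for an effect already at smaller amounts), which is a limit of the assay and not a number.
Compound 2 `O=C(Nc1c(F)cc(F)cc1F)N(Cc1ccccc1)Cc1cccc(-c2cc[nH]n2)c1` gives 0.096 mg/kg.
Compound 3 `O=C(Nc1c(F)cc(F)cc1F)N(Cc1ccc(-c2ccccn2)cc1)C1CCCCCC1` gives > 1 mg/kg, again a limit of the assay.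

Compound 2 and compound 1 differ in one place: 2,4,6-trimethylphenyl in place of 2,4,6-trifluorophenyl on an amide-type nitrogen. This change produced an at least 10-fold higher number from compound 2 to compound 1 (1.01 log units; beyond the scatter), with compound 1 sitting at the limit of > 1 mg/kg in this assay, at which 2 of the 3 values shown sit. Compound 4 `Cc1cc(C)c(NC(=O)N(Cc2ccc(-c3ccccn3)cc2)C2CCCCCC2)c(C)c1` is not yet measured; it stands to compound 3 as compound 1 stands to compound 2, carrying 2,4,6-trimethylphenyl in place of 2,4,6-trifluorophenyl on an amide-type nitrogen at the same place. The difference between the core of compound 3 and the core of compound 2 is not broken down here. The same change at the same place is expected to move the number in the same direction, a step estimated at a step that the limit leaves unreadable from compound 3 to compound 4, resting on compound 1 at the limit of > 1 mg/kg in this assay, at which 2 of the 3 values shown sit, and on an at least 10-fold higher number from compound 2 to compound 1 (1.01 log units; beyond the scatter). Compound 3 already sits at a limit. Compound 4 is therefore expected to give about 3 mg/kg, most likely reported only as a limit.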

Compound 4, dose for half-maximal effect: > 1 mg/kg
Compound 4 was reported as a limit; the forecaster's own chance of this, stated with the estimate: 90%; the middle value is on the limit's open side.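

No step can be read between compound 3 and compound 4, since both are reported only as a limit and not as a number: the limit of > 1 mg/kg in this assay, at which 3 of the 4 values shown sit.

The compounds shown leave open whether swapping 2,4,6-trifluorophenyl for 2,4,6-trimethylphenyl changes the number on the core of compound 3 as it does on the core of compound 2.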